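Swapping the Ring on a Prostaglandin Receptor Ligand

A few compounds are considered here, and "the series" means these few. Any claim that something is new, unique, unknown or untested is made for them only; others in the source may bear on it.

Of the compounds shown here, three built on a shared core have been tested in an assay on membranes from Chem-1 cells for displacement of a labelled ligand from prostaglandin E2 receptor EP3 subtype (Homo sapiens), read by scintillation counting, with a stated time of 2 h; on this read-out lower numbers stand for stronger inhibition and higher numbers for weaker inhibition. Compound 1 `CC(C)[C@H](C[C@H]1OC(=O)NC1=O)c1ccc(-c2ccc3cccc(F)c3c2)[nH]c1=O` gives 6 nM. Compound 2 `C/C(=C1/OC(=O)NC1=O)C(c1ccc(-c2ccc3cccc(F)c3c2)[nH]c1=O)C(C)C` gives 17 nM, and compound 3 `CCC(/C=C1\OC(=O)NC1=O)(CC)c1ccc(-c2ccc3cc(F)cc(F)c3c2)[nH]c1=O` gives 28 nM. Among these three numbers compound 2 stands second highest: its number sits close to that of compound 3, within the usual scatter, so no order between those two can be read, while compound 1 lies clearly lower, beyond the scatter.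

Compound 4 `CC(C)C(c1ccc(-c2ccc3cccc(F)c3c2)[nH]c1=O)C1C(=O)NC(=O)N1C` has not yet been measured in this assay. It differs from compound 2 in a single place: a group of 8 heavy atoms (4 carbon, 2 nitrogen, 2 oxygen; one five-membered non-aromatic ring with 2 hetero atoms) in place of a group of 9 heavy atoms (5 carbon, 1 nitrogen, 3 oxygen; one five-membered non-aromatic ring with 2 hetero atoms), on a saturated chain carbon bound to an aromatic carbon and a saturated chain carbon. The ring that leaves carries one more oxygen and one more double bond outside aromatic rings than the 3-methyl-2,5-dioxoimidazolidin-4-yl that enters, and the count of hydrogen-bond acceptors falls by one, while the single hydrogen-bond donor remains.

For the measured compounds named here, no measured pair shows exactly this exchange, so the size of the step can only be guessed. A modest weakening is expected, with the step from compound 2 to compound 4 estimated at a 2.1-fold higher number from compound 2 to compound 4 (0.31 log units; beyond the scatter). Compound 4 is therefore expected to give about 35 nM in this assay, with a plausible range from 8 nM to 150 nM.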

Compound 4, inhibition constant: 46 nM
Compound 4: the middle estimate sits 1.3-fold (0.12 log units) below what was measured; the measured number falls inside the stated range.
By their numbers in this assay, from the lowest: compound 1; then compounds 2, 3 and 4 (each within the scatter of the next, the first and the last beyond it).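

In this assay, for the compounds shown here, placing the 3-methyl-2,5-dioxoimidazolidin-4-yl on the saturated chain carbon gives a 2.7-fold higher number from compound 2 to compound 4 (0.43 log units; beyond the scatter), the first single-place step in this small set. The step is modest but lies beyond the scatter, so the identity of the five-membered ring at this carbon does register in the read-out, and this ring exchange still leaves a measurable nanomolar number. No measurement shown here explains the shift, and the exchange alters several things at once: one oxygen gives way to a nitrogen, and one double bond outside aromatic rings and one hydrogen-bond acceptor are lost, while the single donor remains.

This one step cannot divide its size among those differences, nor show what the methyl on the entering ring contributes, as no compound shown changes that methyl alone. Going by these compounds, how a simpler group, such as a carboxylic acid or a primary amide, would read on this same carbon in place of either ring also remains open, and so does whether a five-membered ring is needed here at all.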